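A methoxy group added to a lead with a high number in the writhing test

A few compounds are considered here, and "the series" means these few. Any claim that something is new, unique, unknown or untested is made for them only; others in the source may bear on it.

Going by the values given here, the three compounds measured so far share one core and differ in the tail that hangs from it. Compound 1 `COc1ccccc1N1CCN(CCn2c(=O)oc3ncccc32)CC1` gives 52% in a functional assay on the whole organism for inhibition, with Mus musculus as the target, in the writhing test, at a dose of 50 mg/kg by the oral route; a lower number here means less inhibition, a higher number more inhibition at the dose given (going by the name of the read-out). Compound 3 `O=c1oc2ncccc2n1CCCN1CCN(c2cccc3ccccc23)CC1` gives 44% in the same test. Compound 2 `O=c1oc2ncccc2n1CCCN1CCN(c2ccccc2)CC1` stands clearly at the top: it gives 98%, the highest of the three numbers, and both other compounds lie well below it, further apart than repeated measurements usually scatter.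

Compound 4 `COc1ccc(N2CCN(CCCn3c(=O)oc4ncccc43)CC2)cc1` has not yet been measured. It keeps the whole of compound 2 and changes one point: methoxy in place of hydrogen on an aromatic carbon. Among the compounds with values here, no pair among the measured compounds differs in just one place, so no measured step shows what this kind of change does here. Since the number of compound 2 already sits near the top of the percentage scale, there is little room for compound 4 to move upward, and the two lower numbers in the set leave it open whether the number stays level or falls. A downward step from compound 2 to compound 4 of about a number 23 percentage points lower from compound 2 to compound 4 (beyond the scatter) is expected, somewhat beyond the scatter, though a result near that of compound 2 would not be surprising. Compound 4 is therefore estimated at 75%, with a likely range from 40% to 98%.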

Compound 4, a percentage reported as inhibition, in the whole organism at one dose (the size of the read-out at that dose, not a potency): 35%
Beside the measured number, compound 4's estimate is 40 percentage points above it; measured number below the stated range.
By their numbers in this assay, from the lowest: compounds 4, 3 and 1 (each within the scatter of the next, the first and the last beyond it); then compound 2.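

Replacing hydrogen with methoxy on the aromatic ring, para to a large group, gives a number 63 percentage points lower from compound 2 to compound 4 (beyond the scatter) in this assay. Going by these compounds alone, this is the first measured change in this set that touches only one place, so it isolates the effect of this position from the differences among the earlier compounds. It shows that this carbon does not accept every addition: a group of only 2 heavy atoms, with no ring and no net charge, is enough to turn a lead with a very high number into a compound with a far lower one. Nothing available here explains why the number falls.

The compounds shown leave open whether the drop belongs to methoxy itself or would follow any group at this carbon, as a fluorine atom, a methyl group or a hydroxyl group at the same place could tell. They also leave open whether methoxy on another carbon of the same ring would give a similar fall, and whether the gap would hold at other doses, since this read-out reports a single dose and not a potency.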